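This account rests on a few compounds, and the source may have more. Where it says the series, first, only, none or still open, it means among the compounds named here.

Measured so far in an assay on microsomes from intestine for inhibition of acyl-CoA:cholesterol acyltransferase (Oryctolagus cuniculus); on this read-out lower numbers stand for stronger inhibition and higher numbers for weaker inhibition:
compound 1 `Cc1cc(C)c(NC(=O)N(Cc2cccc(-c3nnn(C)n3)c2)C2CCCCCC2)c(C)c1`: 100 nM
compound 2 `Cc1cc(C)c(NC(=O)N(Cc2cccc(-c3cn[nH]c3)c2)C2CCCCCC2)c(C)c1`: 38 nM

Among the measured compounds shown here, compound 2 holds the lowest of the two numbers; its nearest neighbour is compound 1, and the single measured step runs a 2.6-fold lower number from compound 1 to compound 2 (0.42 log units; beyond the scatter), a modest change that lies beyond the scatter.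

Compound 3 `Cc1cc(C)c(NC(=O)N(Cc2cccc(-c3ccn(C)n3)c2)C2CCCCCC2)c(C)c1` differs from compound 2 in one place: 1-methyl-1H-pyrazol-3-yl in place of 1H-pyrazol-4-yl on an aromatic carbon.

For the measured compounds named here, only the step from compound 1 to compound 2 bears on this change, and it does so indirectly. That step exchanged a methylated five-membered azole for an unsubstituted pyrazole and gave the modest lowering noted above. Going by the values given here, compound 3 returns to a methylated azole, although a pyrazole rather than the tetrazole of compound 1, and it also shifts the point of attachment within the ring, for which no measured pair gives guidance. The expectation is therefore a modest rise in the number, a 1.8-fold higher number from compound 2 to compound 3 (0.27 log units; within the scatter), moving toward compound 1 without a firm basis to reach it.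

Compound 3 is estimated at 70 nM in this assay, within a range of 30 nM to 170 nM.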

Compound 3, half-maximal inhibitory concentration: 42 nM
The estimate for compound 3 lay 1.7-fold (0.22 log units) above the measured number; the measured number falls inside the stated range.
By their numbers in this assay, from the lowest: compounds 2 and 3 (each within the scatter of the next); then compound 1.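

In this assay, 1-methyl-1H-pyrazol-3-yl in place of 1H-pyrazol-4-yl on this aromatic carbon, meta to a large group, gives a 1.1-fold higher number from compound 2 to compound 3 (0.04 log units; within the scatter), so this read-out does not separate the two pyrazoles, even though the entering group carries 0 hydrogen-bond donors and the leaving group carries 1. With 1-methyl-1H-pyrazol-3-yl in place of 2-methyl-2H-tetrazol-5-yl, the series shows a 2.4-fold lower number from compound 1 to compound 3 (0.38 log units; beyond the scatter), so a methyl group on the azole does not by itself bring the number back to that of compound 1, and among these three compounds the tetrazole alone stands apart from the pyrazoles. No independent measurement accounts for either step.

Compound 3 differs from compound 2 in both the ring methyl and the point of attachment, so the separate contribution of each remains unresolved, and the two could offset one another. Also open, as far as these compounds go, is how this assay would respond at this position to 1-methyl-1H-pyrazol-4-yl, which would separate those two changes, or to a group outside the azoles, such as a carboxylic acid or a dimethylamino group.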